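The compounds below may be only part of what the source reports. "The series", "measured", "known", "first", "only" and "open" are said of these compounds alone.

Working notes on the series.

Compound 3 `O=C(CCl)Nc1ccc(SCC(=O)Nc2ccc(Br)cn2)cc1` gives 2100 nM in a functional assay on HeLa cells (Homo sapiens) for antiproliferative activity, read by MTT assay, with a stated time of 48 h (on this read-out lower numbers stand for stronger inhibition and higher numbers for weaker inhibition), the lowest of the two numbers reported so far. Its nearest neighbour on this read-out is compound 1 `O=C(CSc1nnc(NC(=O)CCl)s1)Nc1ccc(Cl)cn1`, which gives 3600 nM; the gap between them is within the scatter, so no order is claimed between the two. Compound 2 `O=C(CSc1nnc(NC(=O)CCCCl)s1)Nc1ccc(Cl)cn1` reaches only a limit in this assay, > 80000 nM, and a number is not obtained for it. For the measured compounds named here, the one measured step that differs in a single place, an at least 22-fold higher number from compound 1 to compound 2 (1.34 log units; beyond the scatter), is large; the value sits at the limit of > 80000 nM in this assay, at which 1 of the 3 values shown sits.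

Compound 4 `O=C(CCl)Nc1ccc(SCC(=O)Nc2ccccn2)cc1` differs from compound 3 by hydrogen in place of bromo on an aromatic carbon. Going by the values given here, no measured step concerns a bromo or a change on the six-membered aromatic ring with one nitrogen: the only measured step, an at least 22-fold higher number from compound 1 to compound 2 (1.34 log units; beyond the scatter), alters the saturated chain on the other side of the molecule, so it gives no direct guide to this change. The expectation therefore rests on compound 3 alone, with a step in this assay that is expected to be small, close to the scatter and, if anything, toward a higher number. Compound 4 is expected to give about 3500 nM in this assay, within 1200 nM to 12000 nM, which means an expected step of a 1.7-fold higher number from compound 3 to compound 4 (0.22 log units; within the scatter).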

Compound 4, half-maximal inhibitory concentration: 7800 nM
Estimate against measurement, compound 4: 2.2-fold (0.35 log units) below; low and high end bracket the measured number.
By their numbers in this assay, from the lowest: compounds 3 and 1 (each within the scatter of the next); then compound 4. At a limit, above all of these: compound 2.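

In this assay, the change from 5-bromopyridin-2-yl to pyridin-2-yl gives a 3.7-fold higher number from compound 3 to compound 4 (0.57 log units; beyond the scatter), so on the core of compound 3 the bromo, para to a large group, makes a difference that stands clear of the scatter. For the compounds shown here, this is the first measured step on the six-membered aromatic ring with one nitrogen, and it shows that the number responds to a change on this ring as well as to the change on the saturated chain, although this step is only modest in size. Nothing shown gives a measured reason for the step, so the result stays an observation about this one pair.

The compounds shown leave open whether this step is particular to bromo or would also appear with another group at the same place, such as an amine, a methoxy group or a carboxylic acid. Also open, going by these compounds, is whether removing the chloro from the ring of compound 1 would give a similar step on that core, and how a longer chain in place of the chloro on the saturated carbon would read on the core of compound 3.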